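The source may hold more compounds than are shown below. What is called first, only, known or untested is meant among the compounds shown, and "the series" means these compounds.

Compounds measured so far in a functional assay on HT cells (Homo sapiens) for antiproliferative activity, read by fluorescence, with a stated time of 72 h; a higher number here means a weaker inhibitor of growth, a lower number a stronger inhibitor of growth:

Compound 1 `CC(C)c1n[nH]c2c(NCc3ccc(-c4ccccn4)cc3)nc(SCC(O)CO)nc12` gives 21 nM in this assay.
Compound 2 `CC(O)CSc1nc(NCc2ccc(-c3ccccn3)cc2)c2[nH]nc(C(C)C)c2n1` gives 62 nM in this assay.
Compound 3 `CC(C)c1n[nH]c2c(NCc3ccc(-c4ccccn4)cc3)nc(SC[C@H](O)CN)nc12` gives 63 nM in this assay.

Compound 2 stands second highest of the three numbers; it sits close to compound 3, and compound 1 gives the lowest number. The untested compound 4 `CC(C)c1n[nH]c2c(NCc3ccc(-c4ccccn4)cc3)nc(SCCCN)nc12` differs from compound 2 by 2-aminoethyl in place of 1-hydroxyethyl on a saturated chain carbon bound to a sulfur. Among the compounds with values here, three measured steps bear on this. Removing the hydroxy from compound 1 gave a 3.0-fold higher number from compound 1 to compound 2 (0.47 log units; beyond the scatter). Exchanging a hydroxy for an amino on the same chain gave a 3.0-fold higher number from compound 1 to compound 3 (0.48 log units; beyond the scatter). Adding an amino to the chain of compound 2 gave a 1.0-fold higher number from compound 2 to compound 3 (0.01 log units; within the scatter), so that addition alone did not change the number. The change to compound 4 combines two things already seen: the hydroxy is gone, as in compound 2, and an amino takes its place on the chain, as in compound 3. Since an amino added to compound 2 left the number unchanged, and compound 2 already lacks the hydroxy that compound 1 carries, a small rise or no step beyond the scatter in this assay is expected, that is a 1.6-fold higher number from compound 2 to compound 4 (0.21 log units; within the scatter). Compound 4 is therefore estimated at 100 nM, with a range from 40 nM to 250 nM.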

Compound 4, concentration for 50% growth inhibition: 120 nM
Compound 4: the middle estimate sits 1.2-fold (0.08 log units) below what was measured; the range from low to high includes it.
By their numbers in this assay, from the lowest: compound 1; then compounds 2, 3 and 4 (each within the scatter of the next).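

In this assay, putting 2-aminoethyl in place of 1-hydroxyethyl on the saturated chain carbon bound to a sulfur gives a 1.9-fold higher number from compound 2 to compound 4 (0.29 log units; within the scatter), so this measurement does not tell these two groups apart. Hydrogen in place of the chain hydroxy on the amino-bearing chain gives a 1.9-fold higher number from compound 3 to compound 4 (0.28 log units; within the scatter), and the chain with the 1,2-dihydroxyethyl group remains the only one that stands apart, with a 5.7-fold higher number from compound 1 to compound 4 (0.76 log units; beyond the scatter). Removing one hydroxy now has two readings, one on a chain ending in a hydroxy and one on a chain ending in an amino, and they agree: the same change on two cores in this assay, a 3.0-fold higher number (0.47 log units; beyond the scatter) from compound 1 to compound 2 and a 1.9-fold higher number (0.28 log units; within the scatter) from compound 3 to compound 4, 1.6-fold (0.19 log units) apart, within the scatter of two such steps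

The compounds shown leave open whether a longer chain, such as 4-aminobutyl, or a chain ending in a carboxylic acid or a dimethylamine would keep the number near those of compound 2, compound 3 and compound 4, or come closer to that of compound 1. They also leave open whether the mirror-image form of the chain in compound 3 would give the same number, and whether the 1,2-dihydroxyethyl chain of compound 1 owes its place to one of its two hydroxy groups or needs both.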